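Curcumin enamine analogues: alkyl group on the amine nitrogen

A few compounds are considered here, and "the series" means these few. Any claim that something is new, unique, unknown or untested is made for them only; others in the source may bear on it.

Measured so far:
Compound 1, `C=CCNC(=C\C(=O)/C=C/c1ccc(O)c(OC)c1)/C=C/c1ccc(O)c(OC)c1`, gives 267% in a functional assay on EA.hy 926 cells (Homo sapiens), read by fluorescence, tested at 10 uM; on this read-out higher numbers stand for a stronger effect at the one concentration tested and lower numbers for a weaker effect.
Compound 2, `CCC(C)NC(=C\C(=O)/C=C/c1ccc(O)c(OC)c1)/C=C/c1ccc(O)c(OC)c1`, gives 184% in this assay.
Compound 3, `COc1cc(/C=C/C(=O)/C=C(/C=C/c2ccc(O)c(OC)c2)NC2CCCCC2)ccc1O`, gives 191% in this assay.

Compound 3 stands second highest of the three; its value and that of compound 2 lie within the scatter of each other, while compound 1 is clearly higher. The step of a number 76 percentage points lower from compound 1 to compound 3 (beyond the scatter) and the step of a number 83 percentage points lower from compound 1 to compound 2 (beyond the scatter) are both large, whereas a number 7 percentage points higher from compound 2 to compound 3 (within the scatter) is within the scatter.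

Compound 4, `COc1cc(/C=C/C(=O)/C=C(/C=C/c2ccc(O)c(OC)c2)NCC(C)C)ccc1O`, is not yet measured. It differs from compound 3 in one place: isobutyl in place of cyclohexyl on an amine nitrogen. The step bearing most on this change is a number 7 percentage points higher from compound 2 to compound 3 (within the scatter), which exchanged one branched or saturated alkyl group for another without a change beyond the scatter; the two large steps both concerned the loss of the allyl group, which is not in play here. A step of no more than the scatter is therefore expected, a number 6 percentage points lower from compound 3 to compound 4 (within the scatter). Compound 4 is estimated at 185%, within a range from 150% to 225%.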

Compound 4, a percentage reported as activity, at one concentration (the size of the read-out at that concentration, not a potency): 100%
Compound 4: the middle estimate sits 85 percentage points above what was measured, outside the stated range (below it).
By their numbers in this assay, from the lowest: compound 4; then compounds 2 and 3 (each within the scatter of the next); then compound 1.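

The amine nitrogen proves sensitive to more than the loss of allyl in this assay. The steps of a number 91 percentage points lower from compound 3 to compound 4 (beyond the scatter) and a number 84 percentage points lower from compound 2 to compound 4 (beyond the scatter) show that saturated alkyl groups at this position are not interchangeable, although sec-butyl and cyclohexyl had read alike. The step of a number 167 percentage points lower from compound 1 to compound 4 (beyond the scatter), which reads as isopropyl in place of vinyl on a saturated chain carbon bound to an amine nitrogen, spans all four compounds, with only this one place changed. Nothing shown here accounts for why isobutyl parts from the other groups.

On these data alone, it remains open whether the drop belongs to isobutyl alone or would also appear with a straight n-butyl chain or a cyclopentyl ring on the same nitrogen. As far as these compounds go, it is equally open whether a propargyl group would match allyl.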